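The compounds below may be only part of what the source reports. "The series", "measured", "known", "first", "only" and "open" are said of these compounds alone.

Measured compounds:
- compound 1, `CCC[C@@H](CCO)Nc1nc(N)nc(C)c1Cc1ccc(CNC2CN(C)C2)cc1OC`; in an assay on HEK293 cells for agonist activity at Toll-like receptor 8 (Homo sapiens) (a higher number here means that more compound is needed for the effect, a lower number that less compound is needed), compound 1 gives > 10000 nM, a limit of the assay, not a number.
- compound 2, `CCC[C@@H](CCO)Nc1nc(N)nc(C)c1Cc1ccc(CNCC(N)=O)cc1OC`; in this assay compound 2 gives > 10000 nM, again a limit and not a number.

Compound 2 therefore stands only at a limit: the limit of > 10000 nM in this assay, at which 2 of the 2 values shown sit. For the measured compounds named here, the one measured step, a step that the two limits leave unreadable from compound 1 to compound 2, cannot be read in size or direction, since both of its ends sit at that limit.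

Compound 3, `CCC[C@@H](CCO)Nc1nc(N)nc(C)c1Cc1ccc(CNCCC(N)=O)cc1OC`, differs from compound 2 in one place: carbamoylmethyl in place of carbamoyl on a saturated chain carbon bound to an amine nitrogen. Going by the values given here, of the measured steps only the one from compound 1 to compound 2 touches this part of the structure, and it teaches nothing beyond the limit. Among the compounds with values here, there is thus no measured evidence that a longer chain at this position changes the potency, and no step of a readable size on which to build an expectation.

The expectation for compound 3 is accordingly that it too is reported at the limit, so that the estimated step that the limit leaves unreadable from compound 2 to compound 3 is none that can be read. Compound 3 is estimated at 20000 nM, with a range from 7000 nM to 60000 nM.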

Compound 3, half-maximal effective concentration: > 10000 nM
Compound 3 gave a limit, no number (the forecaster's own chance of this, stated with the estimate: 85%); the middle value lies beyond the limit too.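

Compound 3 also gives a limit and not a number, so the steps among compound 1, compound 2 and compound 3 cannot be read in size or direction: the limit of > 10000 nM in this assay, at which 3 of the 3 values shown sit.

The compounds shown leave open how far apart these three truly lie, and which group on this amine nitrogen, if any, would give a measurable value in this assay.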